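The source may hold more compounds than are shown below. What is called first, only, known or untested is meant among the compounds shown, and "the series" means these compounds.

Measured in a functional assay on HOP-62 cells (Homo sapiens) for inhibition, read by sulforhodamine B assay, with a stated time of 48 h, tested at 10 uM; a lower number here means less inhibition of growth, a higher number more inhibition of growth at the concentration tested:
compound 1, `C/C(=N\O)c1ccc(NC(=O)Cn2nc(-c3ccc(Cl)cc3)nc2N)cc1`, gives 11.7%
compound 2, `c1ccc(-c2nc3sc(-c4ccccc4)cn3n2)cc1`, gives 33%

Compound 2 stands highest of the two numbers in this assay; its nearest neighbour, compound 1, sits a good many points lower, a gap beyond the usual scatter. For the measured compounds named here, no pair of measured compounds differs in a single place, so the change leading to compound 3 has no measured precedent. Compound 3, `Clc1ccc(-c2cn3nc(-c4ccccc4)nc3s2)cc1`, is reached from compound 2 by chloro in place of hydrogen on an aromatic carbon. For this step only a small shift in this assay is expected, most likely upward, though a change that stays within the scatter would not surprise. The expected change reads a number 7 percentage points higher from compound 2 to compound 3 (within the scatter). Compound 3 is accordingly estimated at 40%, with a range of 20% to 60%.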

Compound 3, percent growth inhibition at one concentration: 40%
Beside the measured number, compound 3's estimate shows no gap at the digits printed; the range from low to high includes it.
By their numbers in this assay, from the lowest: compound 1; then compounds 2 and 3 (each within the scatter of the next).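

In this assay, the series now has its first step at a single place: a number 7 percentage points higher from compound 2 to compound 3 (within the scatter), with chloro in place of hydrogen on an aromatic carbon, para to a large group. For the compounds shown here, the phenyl to 4-chlorophenyl change therefore gives a first reading at this position, and on this single pair the chloro leaves growth inhibition at the tested concentration indistinguishable from that with hydrogen. No supporting measurement bears on the reason for this outcome.

On these data alone, whether this position accepts other groups in place of chloro, such as fluoro, methoxy, an amine or a carboxylic acid, remains open. Also open, as far as these compounds go, is whether the same chloro change on the other phenyl group of the shared core would read the same way.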